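A few compounds are considered here, and "the series" means these few. Any claim that something is new, unique, unknown or untested is made for them only; others in the source may bear on it.

Measured in an ADME assay on A549 cells (Homo sapiens) for cytotoxicity, read by MTT assay; on this read-out higher numbers stand for lower toxicity in this test and lower numbers for higher toxicity in this test:
- Compound 1 (`CCCCCCCCCCNc1ccn([C@H]2C[C@H](O)[C@@H](CO)O2)c(=O)n1`): 200000 nM
- Compound 2 (`CCCCCCCCNc1ccn([C@@H]2O[C@H](CO)[C@@H](O)[C@H]2O)c(=O)n1`): 90000 nM

Of these two, compound 2 has the lower number at 90000 nM, and its gap to compound 1 at 200000 nM lies beyond the usual scatter. Compound 3 (`CCCCCCCCCCNc1ccn([C@@H]2O[C@H](CO)[C@@H](O)[C@H]2O)c(=O)n1`) has not yet been measured. Its structure differs from that of compound 2 as follows: ethyl in place of hydrogen on a saturated chain carbon, eight bonds along the chain from a nitrogen on an aromatic ring. In plain terms, this is ethyl in place of hydrogen on a saturated chain carbon, eight bonds along the chain from a nitrogen on an aromatic ring. Going by the values given here, no measured step shows the effect of this change, so the expectation is loose. A small move toward a lower number in this assay is expected, of a size close to the scatter. The expected change is a 1.5-fold lower number from compound 2 to compound 3 (0.18 log units; within the scatter). For compound 3 the estimated value is 60000 nM, with an expected range of 20000 nM to 180000 nM.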

Compound 3, half-maximal cytotoxic concentration: 90000 nM
Estimate against measurement, compound 3: 1.5-fold (0.18 log units) below, within the range that was stated.
By their numbers in this assay, from the lowest: compounds 2 and 3 (each within the scatter of the next); then compound 1.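

In this assay, ethyl in place of hydrogen on a saturated chain carbon, eight bonds along the chain from a nitrogen on an aromatic ring, gives no change at the digits printed from compound 2 to compound 3 (within the scatter), so this added ethyl leaves the read-out unmoved in this pair. Hydroxy in place of hydrogen on a saturated ring carbon gives a 2.2-fold lower number from compound 1 to compound 3 (0.35 log units; beyond the scatter), a modest step toward higher toxicity in this test, and the only new step that clears the scatter. Nothing available here explains either result.

On these data alone, whether a longer chain or an amine at the same place on the chain would move the number beyond the scatter remains open. As far as these compounds go, it is also open whether the hydroxy step would hold with a different chain, as it rests on one pair only.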